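Swapping the halogenated phenyl ether on a shared core

The compounds below may be only part of what the source reports. "The series", "measured", "known", "first", "only" and "open" are said of these compounds alone.

Three compounds have been measured in an assay on cells (Hepatocyte, strain Sprague-Dawley) for inhibition of acyl-CoA desaturase 1 (Rattus norvegicus), read by HPLC; on this read-out lower numbers stand for stronger inhibition and higher numbers for weaker inhibition:
Compound 1 `O=C(O)c1cncc(-c2ccc(N3CCC(Oc4ccccc4C(F)(F)F)CC3)nn2)c1` gives 1300 nM.
Compound 2 `O=C(O)c1cncc(-c2ccc(N3CCC(Oc4ccccc4Cl)CC3)nn2)c1` gives 1890 nM.
Compound 3 `O=C(O)c1cncc(-c2ccc(N3CCC(Oc4ccccc4I)CC3)nn2)c1` gives 1000 nM.

All three share the same core and differ only in the group attached to the phenyl ether. Compound 2 has the largest of the three numbers, but its separation from the others is small: the step of a 1.5-fold higher number from compound 1 to compound 2 (0.16 log units; within the scatter) and the step of a 1.9-fold lower number from compound 2 to compound 3 (0.28 log units; within the scatter) both fall within the scatter, as does the step of a 1.3-fold lower number from compound 1 to compound 3 (0.11 log units; within the scatter). So far, exchanging one halogen-type substituent for another on this aromatic carbon has not moved the read-out beyond what repeated measurements would show.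

Compound 4 `O=C(O)c1cncc(-c2ccc(N3CCC(Oc4cc(F)ccc4Br)CC3)nn2)c1` introduces a new variation: 2-bromo-5-fluorophenyl in place of 2-chlorophenyl on an oxygen on a saturated carbon. Bromo is a halogen like the chloro and iodo already tried, and the added fluoro is a further halogen on the same ring. Because the measured steps of a 1.9-fold lower number from compound 2 to compound 3 (0.28 log units; within the scatter) and a 1.5-fold higher number from compound 1 to compound 2 (0.16 log units; within the scatter) stayed within the scatter, the expectation for compound 4 is a step of a 1.4-fold lower number from compound 2 to compound 4 (0.13 log units; within the scatter) that is not beyond the scatter. Compound 4 is therefore estimated at 1400 nM, with a plausible range from 600 nM to 3500 nM.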

Compound 4, half-maximal inhibitory concentration: 175 nM
For compound 4 the middle estimate is 8.0-fold (0.90 log units) above the measured one; the whole stated range lies above it.
By their numbers in this assay, from the lowest: compound 4; then compounds 3, 1 and 2 (each within the scatter of the next).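

In this assay this place on the oxygen of the shared core, which had seemed insensitive to the earlier exchanges, proves able to move the read-out: the 2-bromo-5-fluorophenyl group gives an 11-fold lower number from compound 2 to compound 4 (1.03 log units; beyond the scatter) and also a 5.7-fold lower number from compound 3 to compound 4 (0.76 log units; beyond the scatter) as well as a 7.4-fold lower number from compound 1 to compound 4 (0.87 log units; beyond the scatter) and all three steps lie beyond the scatter. Among these compounds, each earlier exchange replaced one group on the ring with another, whereas this change brings in a bromo group and adds a fluoro group at once, and only this combined change has given a step larger than the scatter. No measurement here explains the gain.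

The compounds shown leave open whether the bromo group, the added fluoro group or the two together account for the step, since no compound carries either change alone. A 2-bromophenyl group and a 2-chloro-5-fluorophenyl group on the same core would separate those possibilities, while a 2-bromo-5-methoxyphenyl or 2-bromo-5-cyanophenyl group would show whether that second group must be a fluoro group.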